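The source may report more compounds than this note shows. Statements on the series, on what has been measured and on what is new or still open speak of the compounds shown alone.

Series notes. The shared core of compound 1 `CCCCOc1ccc(-c2nc3ncccn3c2NC(C)(C)CC(C)(C)C)cc1` carries butoxy on an aromatic carbon and 1,1,3,3-tetramethylbutyl on a nitrogen on an aromatic ring; in a toxicity assay on A549 cells (Homo sapiens) for cytotoxicity, read by luminescence and CellTiter-Glo, with a stated time of 48 h (a lower number here means that less compound is tolerated, a higher number that more compound is tolerated), compound 1 gives 29000 nM. Compound 2 `CCCCOc1ccc(-c2nc3ncccn3c2NCc2nc[nH]c2C)cc1` has (5-methyl-1H-imidazol-4-yl)methyl on that nitrogen instead, and in this assay compound 2 gives 100000 nM; the step is a 3.4-fold higher number from compound 1 to compound 2 (0.54 log units; beyond the scatter). Compound 3 `CC(C)(C)CC(C)(C)Nc1c(-c2ccc(Br)cc2)nc2ncccn12` keeps the 1,1,3,3-tetramethylbutyl but has bromo in place of butoxy; in this assay compound 3 gives 32000 nM, and the step is a 1.1-fold higher number from compound 1 to compound 3 (0.04 log units; within the scatter). Among the three numbers compound 3 stands second highest: compound 1 lies within the scatter of it, compound 2 beyond it.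

Compound 4 `Brc1ccc(-c2nc3ncccn3c2Nc2ccccc2)cc1` differs from compound 3 in one place: phenyl in place of 1,1,3,3-tetramethylbutyl on a nitrogen on an aromatic ring. For the measured compounds named here, no measured step swaps this alkyl group for phenyl. The step that bears on it is the exchange of the same alkyl group at the same nitrogen, a 3.4-fold higher number from compound 1 to compound 2 (0.54 log units; beyond the scatter), which was modest; the bromo-for-butoxy exchange, a 1.1-fold higher number from compound 1 to compound 3 (0.04 log units; within the scatter), left the number unchanged, so the two starting points look alike. A modest rise in this assay is therefore expected, of the size a 1.6-fold higher number from compound 3 to compound 4 (0.19 log units; within the scatter). Compound 4 is expected in this assay at 50000 nM, between 20000 nM and 110000 nM.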

Compound 4, half-maximal cytotoxic concentration: > 100000 nM
Compound 4 gave a limit, no number (the forecaster's own chance of this, stated with the estimate: 25%); at least 2.0-fold (0.30 log units) between middle value and limit.
By their numbers in this assay, from the lowest: compounds 1 and 3 (each within the scatter of the next); then compound 2.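

At the nitrogen on an aromatic ring, phenyl in place of 1,1,3,3-tetramethylbutyl gives an at least 3.1-fold higher number from compound 3 to compound 4 (0.49 log units; beyond the scatter) in this assay, so a change at this nitrogen moves the number beyond the scatter with bromo on the aromatic carbon, whereas the exchange of that aromatic-carbon group itself gave a 1.1-fold higher number from compound 1 to compound 3 (0.04 log units; within the scatter). The only earlier exchange at this nitrogen, a 3.4-fold higher number from compound 1 to compound 2 (0.54 log units; beyond the scatter), carried butoxy on the aromatic carbon; both exchanges of 1,1,3,3-tetramethylbutyl shown now point the same way, with no compound shown going against it, and the new one does so with a six-membered aromatic ring of carbon only on the nitrogen. For compound 4 the entry > 100000 nM is a limit and not a number, so the step has a lower bound only: the limit of > 100000 nM in this assay, at which 1 of the 4 values shown sits.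

Open, going by these compounds, is whether the rise follows the loss of 1,1,3,3-tetramethylbutyl or the entry of the aromatic ring, which a cyclohexyl or a short chain such as ethyl on this nitrogen would separate. Also open, on these data alone, are phenyl on this nitrogen with butoxy on the aromatic carbon, and a phenyl carrying an amine or a carboxylic acid.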